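Cell tolerance after swapping the aryl group on the ring nitrogen

The source may report more compounds than this note shows. Statements on the series, on what has been measured and on what is new or still open speak of the compounds shown alone.

Compound 1 `Cc1ccc(-n2cc(CNCCN3CCN(C)CC3)c(-c3ccccc3C)n2)c(C)c1`: a limit only, > 20000 nM, in an ADME assay on Huh-7 cells (Homo sapiens) for cytotoxicity; a higher number here means that more compound is tolerated, a lower number that less compound is tolerated.
Compound 2 `Cc1ccccc1-c1nn(-c2cccc(Cl)c2)cc1CNCCN1CCN(C)CC1`: 16000 nM in this assay.

Compound 2 holds the only number shown in this assay; the other value is a limit, and compound 1 sits at that limit (the limit of > 20000 nM in this assay, at which 1 of the 2 values shown sits). Among the compounds with values here, the single measured step, an at least 1.2-fold lower number from compound 1 to compound 2 (0.09 log units; that floor lies within the scatter), stays within the scatter. Compound 3 `Cc1ccccc1-c1nn(-c2ccc([N+](=O)[O-])cc2)cc1CNCCN1CCN(C)CC1` carries 4-nitrophenyl in place of 3-chlorophenyl on an aromatic nitrogen. Within the data shown here, no measured step exchanges these two aryl groups, and the one step that changed this aryl group did not move the number beyond the scatter. Compound 3 is therefore expected to show no change at the digits printed from compound 2 to compound 3 (within the scatter), none beyond the scatter. Compound 3 is estimated at 16000 nM, from 8000 nM to 30000 nM.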

Compound 3, half-maximal cytotoxic concentration: > 20000 nM
Compound 3 was reported as a limit; the forecaster's own chance of this, stated with the estimate: 30%; middle value at least 1.2-fold (0.09 log units) from the limit.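

Putting 4-nitrophenyl in place of 3-chlorophenyl on the aromatic nitrogen gives an at least 1.2-fold higher number from compound 2 to compound 3 (0.09 log units; that floor lies within the scatter) in this assay, so a second kind of aryl group at this position shows no step beyond the scatter. Compound 3 gives only a limit, > 20000 nM, and the step between compound 1 and compound 3 cannot be read. Most values shown now sit at that limit: the limit of > 20000 nM in this assay, at which 2 of the 3 values shown sit.

As far as these compounds go, whether an amine or a carboxylic acid on this aryl group would lower the number beyond the scatter stays open. So does the true size of the step to compound 3.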